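This account rests on a few compounds, and the source may have more. Where it says the series, first, only, none or still open, it means among the compounds named here.

The measured compounds and their values in an ADME assay on HepG2 cells (Homo sapiens) for cytotoxicity, with a stated time of 72 h; a lower number here means that less compound is needed, a higher number that more compound is needed for the effect:

Compound 1, `Cc1cc(NC(=O)Nc2cccc(Cl)c2)c2ccccc2n1`: 19000 nM
Compound 2, `COC(=O)c1ccc(NC(=O)Nc2cc(C)nc3ccccc23)cc1`: 20000 nM
Compound 3, `Cc1cc(NC(=O)Nc2ccc(Cl)cc2)c2ccccc2n1`: > 25000 nM, which is a limit of this assay rather than a number

All three compounds share a core and differ only in the aryl group on the urea. For compound 3 this assay reports only a limit, so its exact standing among the three is not known; the step of an at least 1.3-fold higher number from compound 1 to compound 3 (0.11 log units; that floor lies within the scatter) and the step of an at least 1.2-fold higher number from compound 2 to compound 3 (0.09 log units; that floor lies within the scatter) are both floors that lie within the scatter of this assay, and the values of compound 1 and compound 2 lie within the scatter of each other. Compound 3 thus sits at the limit (the limit of > 25000 nM in this assay, at which 1 of the 3 values shown sits).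

Compound 4, `Cc1cc(NC(=O)Nc2ccc(Cl)cc2Cl)c2ccccc2n1`, differs from compound 3 in one place: chloro in place of hydrogen on an aromatic carbon. The two measured steps into compound 3 were small, each changing the aryl group without a step beyond the scatter. Among the measured compounds shown here, for the added chloro no measured step exists, so the step expected in this assay is a number no higher from compound 3 to compound 4 (the limit leaves the size open), none beyond the scatter. Compound 4 is therefore estimated at 25000 nM, between 10000 nM and 60000 nM, most likely again reported only as a limit.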

Compound 4, half-maximal effective concentration: 16000 nM
Estimate against measurement, compound 4: 1.6-fold (0.19 log units) above; low and high end bracket the measured number.
By their numbers in this assay, from the lowest: compounds 4, 1 and 2 (each within the scatter of the next). At a limit, above all of these: compound 3.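

In this assay, chloro in place of hydrogen at this position, ortho to a large group and meta to a chloro group, gives an at least 1.5-fold lower number from compound 3 to compound 4 (0.19 log units; that floor lies within the scatter). Unlike the two earlier steps into compound 3, which pointed upward, this one points downward, so the added chloro does not push the number higher, though the true size of the step stays unknown. For compound 3, > 25000 nM is a limit and not a number: the limit of > 25000 nM in this assay, at which 1 of the 4 values shown sits.

As far as these compounds go, whether a different group at this position, such as a methyl, a methoxy or an amine, would shift the number in the same direction remains open. Also open, from the compounds shown here alone, is what this added chloro would do on a ring without the chloro group already present in compound 3.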